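Adding an ethyl group to an acid side chain

The source may report more compounds than this note shows. Statements on the series, on what has been measured and on what is new or still open speak of the compounds shown alone.

- compound 1 (`O=C(O)Cc1nn(Cc2cn3cc(OCC4CC4)c(Cl)cc3n2)c2ccccc2c1=O`) gives 2010000 nM
- compound 2 (`C[C@H](C(=O)O)n1nc(Cn2cc3cc(OCC4CC4)c(Cl)cc3n2)c2ccccc2c1=O`) gives 4750000 nM

In an ADME assay on the whole organism (Mus musculus, strain CD1) for pharmacokinetics, read by LC-MS, with a stated time of 24 h, at a dose of 5 mg/kg by the oral route (a higher number here means more compound in the circulation at the dose given, a lower number less compound in the circulation), compound 1 stands lowest of the two measured compounds, and the gap up to compound 2 lies beyond the scatter. Compound 3 (`CCC(C(=O)O)c1nn(Cc2cn3cc(OCC4CC4)c(Cl)cc3n2)c2ccccc2c1=O`) keeps the core of compound 1 but has ethyl in place of hydrogen on a saturated chain carbon bound to an aromatic carbon and a carbonyl carbon, so carboxymethyl becomes 1-carboxypropyl. Going by the values given here, no two measured compounds differ in one place only, so no measurement sizes this change directly. Compound 1 differs from compound 2 in more than one place, so the value of compound 2 at 4750000 nM offers only a weak hint of an upward move. A small rise in this assay is expected, probably within the scatter. The expected step is a 1.5-fold higher number from compound 1 to compound 3 (0.17 log units; within the scatter) and no larger move is assumed. For compound 3 the estimated value is 3000000 nM with 1200000 nM to 7500000 nM as its expected range.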

Compound 3, maximal plasma concentration: 2210000 nM
Estimate against measurement, compound 3: 1.4-fold (0.13 log units) above; the measured number falls inside the stated range.
By their numbers in this assay, from the lowest: compounds 1 and 3 (each within the scatter of the next); then compound 2.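

In this assay, putting ethyl in place of hydrogen on a saturated chain carbon bound to an aromatic carbon and a carbonyl carbon gives a 1.1-fold higher number from compound 1 to compound 3 (0.04 log units; within the scatter). Going by these compounds alone, this pair is the only direct reading of a change at this position, and it shows that carboxymethyl can become 1-carboxypropyl without a difference that this measurement can distinguish from ordinary scatter. Nothing available explains why the two compounds read alike.

This single pair cannot show whether the position would tolerate other groups in the same way, such as a longer chain like butyl, a cyclopropyl ring or an amine. Compound 2 differs from both compounds in more than one place, so the reason for its separate value remains open.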